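Trifluoromethyl on the Saturated Ring, Carried to a Second Core

A few compounds are considered here, and "the series" means these few. Any claim that something is new, unique, unknown or untested is made for them only; others in the source may bear on it.

Of the compounds shown here, three have been measured in a functional assay on cells for agonist activity at Free fatty acid receptor 1 (Mus musculus), read by FLIPR and calcium flux, with a stated time of 100 s; on this read-out lower numbers stand for an effect already at smaller amounts and higher numbers for an effect only at larger amounts of compound. Compound 2 `Cc1ccccc1Oc1ccc(N2CCC[C@H]2CC(=O)O)cc1` gives 5600 nM in this assay. Compound 1 `Cc1ccccc1Oc1ccc(N2C[C@@H](C(F)(F)F)C[C@H]2CC(=O)O)cc1` carries trifluoromethyl in place of hydrogen on a saturated ring carbon and in this assay compound 1 gives 330 nM; the step is a 17-fold lower number from compound 2 to compound 1 (1.23 log units; beyond the scatter). Compound 3 `COc1ccc(F)c(-c2ccc(Cc3ccc(N4CCC[C@H]4CC(=O)O)cc3)c(C)c2)c1` is built on a different core, and the difference between the two cores is not broken down here. In this assay compound 3 gives 1900 nM, a number that lies between those of compound 2 and compound 1.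

Compound 4 `COc1ccc(F)c(-c2ccc(Cc3ccc(N4C[C@@H](C(F)(F)F)C[C@H]4CC(=O)O)cc3)c(C)c2)c1` has not yet been measured. It differs from compound 3 by trifluoromethyl in place of hydrogen on a saturated ring carbon, at a place described in exactly the same words as for the change from compound 2 to compound 1, so the two changes are the same. Among the measured compounds shown here, whether the change gives the same step on the core of compound 3 cannot be read from these compounds, as only one measured pair carries it. The expectation rests on that pair, because the step of a 17-fold lower number from compound 2 to compound 1 (1.23 log units; beyond the scatter) lay well beyond the scatter. For compound 4 a step in the same direction is expected, estimated as a 15-fold lower number from compound 3 to compound 4 (1.16 log units; beyond the scatter). For the measured compounds named here, only one pair supports the transfer, and the estimate is made somewhat smaller than the measured step, with a wide range. Compound 4 is expected to give about 130 nM in this assay, with the range 40 nM to 450 nM.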

Compound 4, half-maximal effective concentration: 2400 nM
Beside the measured number, compound 4's estimate is 18-fold (1.27 log units) below it, and the stated range ends below it.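

In this assay, among the compounds shown here, trifluoromethyl in place of hydrogen on a saturated ring carbon gives a 1.3-fold higher number from compound 3 to compound 4 (0.10 log units; within the scatter), so on this second core the change produces no step that stands clear of the scatter. Set side by side, the two results show that the large step seen on the first core did not carry over to the second, and that the same change cannot be assumed to give the same step across these two cores: the same change on two cores in this assay, a 17-fold lower number (1.23 log units; beyond the scatter) from compound 2 to compound 1 and a 1.3-fold higher number (0.10 log units; within the scatter) from compound 3 to compound 4, 21-fold (1.33 log units) apart, beyond the scatter of two such steps. This does not show which part of the core of compound 3 sets the two steps apart, and two pairs give no rule for how the change would behave on any further core.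

The compounds shown leave open whether a compound carrying only part of the difference between the two cores would keep the large step or lose it. They also leave open whether a methyl group or a single fluorine on the same saturated ring carbon would follow trifluoromethyl on either core.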